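Trimming the Sulfonamide Chain: Stability Outlook for Compound 3

The compounds below may be only part of what the source reports. "The series", "measured", "known", "first", "only" and "open" are said of these compounds alone.

Compound 1 `O=C(NS(=O)(=O)CCNC(=O)C1CC1)c1ccc(Nc2nc(NC3(c4ccc(Cl)cc4)CC3)nc(OCC(F)(F)F)n2)cc1` gives 90% in an ADME assay on microsomes from liver (Homo sapiens) for metabolic stability, with a stated time of 10 min; on this read-out lower numbers stand for a less stable compound and higher numbers for a more stable compound.
Compound 2 `CC(=O)NCCS(=O)(=O)NC(=O)c1ccc(Nc2nc(NC3(c4ccc(Cl)cc4)CC3)nc(OCC(F)(F)F)n2)cc1` gives 95% in this assay.

Compound 2 and compound 1 lie within the scatter of each other: a number 5 percentage points higher from compound 1 to compound 2 (within the scatter). Compound 3 `CS(=O)(=O)NC(=O)c1ccc(Nc2nc(NC3(c4ccc(Cl)cc4)CC3)nc(OCC(F)(F)F)n2)cc1` differs from compound 2 by hydrogen in place of acetamidomethyl on a saturated chain carbon bound to a sulfonyl sulfur. For the measured compounds named here, no measured step removes this group; the only measured step, methyl in place of cyclopropyl on a carbonyl carbon, changed a neighbouring part and stayed within the scatter. On that basis no step beyond the scatter is expected in this assay. Compound 3 is therefore estimated at 90% (range 70% to 99%), an expected step of a number 5 percentage points lower from compound 2 to compound 3 (within the scatter).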

Compound 3, percent of the compound remaining: 100%
Beside the measured number, compound 3's estimate is 10 percentage points below it; measured number above the stated range.
By their numbers in this assay, from the lowest: compounds 1, 2 and 3 (each within the scatter of the next).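

The earlier pair changed only the group on the carbonyl carbon, whereas here the whole side group goes: hydrogen in place of acetamidomethyl on a saturated chain carbon bound to a sulfonyl sulfur gives a number 5 percentage points higher from compound 2 to compound 3 (within the scatter) in this assay. Hydrogen in place of ((cyclopropylcarbonyl)amino)methyl at that carbon gives a number 10 percentage points higher from compound 1 to compound 3 (within the scatter), so in this read-out neither group is needed for the number to stay within the scatter. Nothing in the data shown explains this result. As far as these compounds go, whether an amine or a carboxylic acid at this carbon would also stay within the scatter remains open.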